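This account rests on a few compounds, and the source may have more. Where it says the series, first, only, none or still open, it means among the compounds named here.

Compound 1 `COc1cc2c(c(OC)c1OC)CCN(CCCCC(=O)c1c(C)c(OC)c(OC)c(OC)c1OC)C2` gives 34.2 nM in an assay on membranes from liver for displacement of a labelled ligand from Sigma intracellular receptor 2 (Rattus norvegicus), read by scintillation counting, with a stated time of 120 min; on this read-out higher numbers stand for weaker inhibition and lower numbers for stronger inhibition; compound 2 `COc1cc2c(cc1OC)CN(CCCCCC(=O)c1c(C)c(OC)c(OC)c(OC)c1OC)CC2` gives 0.38 nM in this assay; compound 3 `COc1cc2c(cc1OC)CN(CCCCCCC(=O)c1c(C)c(OC)c(OC)c(OC)c1OC)CC2` gives 1.33 nM in this assay.

Among these three numbers, compound 3 holds the second highest value: it sits beyond the scatter from compound 2 in the weaker direction and far beyond the scatter from compound 1 in the stronger direction. Compound 4 `COc1cc2c(c(OC)c1OC)CCN(CCCCCCC(=O)c1c(C)c(OC)c(OC)c(OC)c1OC)C2` has not yet been measured in this assay. It differs from compound 3 by methoxy in place of hydrogen on an aromatic carbon. Going by the values given here, no measured pair shows this single change on its own, so its size cannot be read directly. Compound 1 carries the same additional methoxy on its core together with a shorter chain, and its value of 34.2 nM stands well above those of compound 2 and compound 3, while compound 3 at 1.33 nM keeps the longer chain that compound 4 also bears. Compound 4 is therefore expected to come out weaker than compound 3, with a step from compound 3 to compound 4 of about a 4.5-fold higher number from compound 3 to compound 4 (0.65 log units; beyond the scatter). The estimate for compound 4 in this assay is 6 nM, with a range from 1.2 nM to 40 nM.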

Compound 4, inhibition constant: 40 nM
Compound 4: the middle estimate sits 6.7-fold (0.82 log units) below what was measured; low and high end bracket the measured number.
By their numbers in this assay, from the lowest: compound 2; then compound 3; then compounds 1 and 4 (each within the scatter of the next).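

The pair of compound 3 and compound 4 isolates a single change, a methoxy on an aromatic carbon ortho to a fused ring and ortho to a methoxy group, and in this assay this change alone gives a 30-fold higher number from compound 3 to compound 4 (1.48 log units; beyond the scatter) in the weaker direction. With this methoxy present, compound 1 at 34.2 nM and compound 4 at 40 nM lie within the scatter of each other, although compound 1 has the shorter chain. Nothing shown here offers an explanation for the size of this step.

The compounds shown leave open whether a smaller group, such as fluorine or hydroxyl, on this aromatic carbon would give a step of similar size. They also leave open whether the methoxy has the same effect on the shorter chain of compound 1.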